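Bromoacrylamide chalcones: aryl ketone variation, antiproliferative read-out

The source may report more compounds than this note shows. Statements on the series, on what has been measured and on what is new or still open speak of the compounds shown alone.

Measured so far:
compound 1, `C=C(Br)C(=O)Nc1ccc(/C=C/C(=O)c2ccc(F)cc2)cc1`, 1100 nM
compound 2, `C=C(Br)C(=O)Nc1ccc(/C=C/C(=O)c2ccc(C)cc2)cc1`, 1800 nM

Both numbers come from an ADME assay on CCRF-CEM cells (Homo sapiens) for antiproliferative activity, with a stated time of 48 h; on this read-out lower numbers stand for stronger inhibition and higher numbers for weaker inhibition. Compound 2 holds the higher of the two numbers, its nearest neighbour being compound 1; the step of a 1.6-fold higher number from compound 1 to compound 2 (0.21 log units; within the scatter) lies within the scatter. Compound 3, `C=C(Br)C(=O)Nc1ccc(/C=C/C(=O)c2cccc(OC)c2)cc1`, differs from compound 2 by 3-methoxyphenyl in place of 4-methylphenyl on a carbonyl carbon. Among the measured compounds shown here, the one measured step, from a fluoro to a methyl on the same aryl ring, changed little, and no step that swaps the substitution pattern of this aryl ring has been measured. No change beyond the scatter is therefore expected in this assay, with an estimated no change at the digits printed from compound 2 to compound 3 (within the scatter). Compound 3 is estimated at 1800 nM, within 700 nM to 4500 nM.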

Compound 3, half-maximal inhibitory concentration: 2300 nM
For compound 3 the middle estimate is 1.3-fold (0.11 log units) below the measured one; the measured number falls inside the stated range.
By their numbers in this assay, from the lowest: compounds 1, 2 and 3 (each within the scatter of the next, the first and the last beyond it).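

In this assay, 3-methoxyphenyl in place of 4-methylphenyl on the carbonyl carbon gives (a 1.3-fold higher number from compound 2 to compound 3 (0.11 log units; within the scatter)), so this first change of substitution pattern on the aryl ring does not separate the two compounds. Against 4-fluorophenyl, the same group gives (a 2.1-fold higher number from compound 1 to compound 3 (0.32 log units; beyond the scatter)), the first step in the series beyond the scatter, though a modest one. Nothing available accounts for either step. Going by these compounds, whether the methoxy group itself or its placement on the ring sets this gap remains open, since the two differ together here. Also open, on these data alone, is how an amine or a carboxylic acid on this aryl ring would read.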